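The compounds below may be only part of what the source reports. "The series", "measured", "known", "first", "only" and "open" are said of these compounds alone.

Compound 2 `CC(Oc1ccc(Oc2ccc(Cl)cc2)cc1)C(=O)Cn1nnc(-c2ccc(Cl)cc2)n1` gives 76 nM in an assay on microsomes from brain for inhibition of Fatty-acid amide hydrolase 1 (Rattus norvegicus), read by fluorescence and HPLC, with a stated time of 60 min (on this read-out higher numbers stand for weaker inhibition and lower numbers for stronger inhibition), and stands between compound 1 `CCCCCCCCc1ccc(OC(C)C(=O)Cn2nnc(-c3ccc(Cl)cc3)n2)cc1` at 35 nM and compound 3 `CC(Oc1ccc(Oc2ccc(C(F)(F)F)cc2)cc1)C(=O)Cn1nnc(-c2ccc(Cl)cc2)n1` at 300 nM. Compound 4 `CC(Oc1ccc(Oc2ccc(Cl)cc2)cc1)C(=O)Cn1nnc(-c2ccc(C(=O)O)cc2)n1` differs from compound 2 by carboxy in place of chloro on an aromatic carbon. The measured steps all fall at the other end of the shared core: a 2.2-fold higher number from compound 1 to compound 2 (0.34 log units; beyond the scatter), an 8.6-fold higher number from compound 1 to compound 3 (0.93 log units; beyond the scatter) and a 3.9-fold higher number from compound 2 to compound 3 (0.60 log units; beyond the scatter). For the measured compounds named here, none of them alters the 4-chlorophenyl end, so no measured step bears directly on the present change, and the series itself says nothing about a carboxy group anywhere. The change is nevertheless expected to move the number upward, more than any step seen so far: an 11-fold higher number from compound 2 to compound 4 (1.02 log units; beyond the scatter). Compound 4 is estimated at 800 nM, with a range of 150 nM to 5000 nM.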

Compound 4, half-maximal inhibitory concentration in the Fatty-acid amide hydrolase 1 assay: 90 nM
The estimate for compound 4 lay 8.9-fold (0.95 log units) above the measured number; measured number outside the range, below it.
By their numbers in the Fatty-acid amide hydrolase 1 assay, from the lowest: compound 1; then compounds 2 and 4 (each within the scatter of the next); then compound 3.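

For the compounds shown here, in the Fatty-acid amide hydrolase 1 assay, carboxy in place of chloro gives a 1.2-fold higher number from compound 2 to compound 4 (0.07 log units; within the scatter), so this end, untouched by the earlier steps, accepts the swap with no difference that can be read. The same swap is far from silent in a physicochemical assay for lipophilicity, read by HPLC, tested at 5 mM (on this read-out higher numbers stand for higher lipophilicity and lower numbers for lower lipophilicity), where compound 2 gives 6.8 and compound 4 gives 3.3: the measured partition coefficient of compound 2, 6.8, and of compound 4, 3.3, a number 3.50 log units lower (beyond the scatter). For this pair, inhibition therefore does not follow the partition coefficient.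

Going by these compounds, whether other groups at this place, such as an amine or a primary amide, behave alike stays open. So does whether carboxy here is accepted with the octyl group of compound 1 at the other end.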